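The source may report more compounds than this note shows. Statements on the series, on what has been measured and on what is new or still open speak of the compounds shown alone.

Measured compounds:

compound 1 `CN1CCN(C23CCN(CCCN4CCCCC4)C(C(c4ccccc4)C2)C(c2ccccc2)C3)CC1` — in an ADME assay on L6 cells (Rattus norvegicus) for cytotoxicity, read by fluorescence, with a stated time of 72 h (on this read-out higher numbers stand for weaker inhibition and lower numbers for stronger inhibition), compound 1 gives 28900 nM

compound 2 `CCN(CC)CCCN1CCC2(N3CCN(C)CC3)CC(c3ccccc3)C1C(c1ccccc1)C2` — in this assay compound 2 gives 68100 nM

Going by the values given here, compound 2 holds the highest of the two numbers; its only neighbour is compound 1, and the single measured step between them is a 2.4-fold higher number from compound 1 to compound 2 (0.37 log units; beyond the scatter). Compound 3 `CN1CCN(C23CCN(CCCN4CCCC4)C(C(c4ccccc4)C2)C(c2ccccc2)C3)CC1` is not yet measured in this assay. Its difference from compound 2 is pyrrolidin-1-yl in place of diethylamino on a saturated chain carbon, three bonds along the chain from an amine nitrogen in a ring. Among the compounds with values here, the one step that bears on this is the step from compound 1 to compound 2, which went beyond the scatter when piperidin-1-yl gave way to diethylamino at this place. Compound 3 brings a ring amine back at the same place, pyrrolidin-1-yl rather than the piperidin-1-yl of compound 1, so a step in the opposite direction, back toward the number of compound 1, is expected, probably of similar or somewhat smaller size: a 1.9-fold lower number from compound 2 to compound 3 (0.28 log units; within the scatter). Compound 3 is thus estimated to give 36000 nM in this assay, with a range from 15000 nM to 90000 nM, the uncertainty resting on a single step from two compounds.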

Compound 3, half-maximal inhibitory concentration: 43500 nM
Compound 3: middle estimate off by 1.2-fold (0.08 log units), on the low side, and the stated range covers the measured number.
By their numbers in this assay, from the lowest: compounds 1, 3 and 2 (each within the scatter of the next, the first and the last beyond it).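

In this assay, the change at this place on a saturated chain carbon, three bonds along the chain from an amine nitrogen in a ring, now has a third terminal group, and the earlier single step no longer reads as a simple contrast between ring amines and diethylamino. Exchanging diethylamino for pyrrolidin-1-yl keeps the count of 5 heavy atoms and adds a ring, yet the step stays within the scatter (a 1.6-fold lower number from compound 2 to compound 3 (0.19 log units; within the scatter)). Going by these compounds alone, exchanging piperidin-1-yl for pyrrolidin-1-yl also stays within the scatter (a 1.5-fold higher number from compound 1 to compound 3 (0.18 log units; within the scatter)), so compound 3 cannot be separated from compound 1 or compound 2, and only the step between those two goes beyond the scatter. No measurement at hand gives a reason for these numbers.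

The compounds shown leave open whether a morpholin-4-yl group or a dimethylamino group at this place would go beyond the scatter relative to these three. They also leave open whether a longer chain carrying the same terminal amines would shift the number in this assay.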